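Swapping a Methylpyridine for a Fluoropyridine: Lipophilicity Outlook

The source may report more compounds than this note shows. Statements on the series, on what has been measured and on what is new or still open speak of the compounds shown alone.

Within the data shown here, in a physicochemical assay for lipophilicity, read by LC-MS, in phosphate buffer, measured as octanol-water partition, with a stated time of 30 min, at pH 7.4, tested at 200 mM (on this read-out higher numbers stand for higher lipophilicity and lower numbers for lower lipophilicity), compound 3 `Cc1cccnc1Oc1ccc2nc(COc3cccc(C(=O)O)c3)n(C)c2c1` gives 0.9, the highest of the three numbers so far. Compound 2 `Cc1ccnc(Oc2ccc3nc(COc4cccc(C(=O)O)c4)n(C)c3c2)c1` gives 0.8, and compound 1 `Cn1c(COc2cccc(C(=O)O)c2)nc2ccc(Oc3ccccn3)cc21` gives 0.4. Adding a methyl raised this assay each time: a number 0.40 log units higher from compound 1 to compound 2 (beyond the scatter) and a number 0.50 log units higher from compound 1 to compound 3 (beyond the scatter), while a number 0.10 log units higher from compound 2 to compound 3 (within the scatter). Compound 4 `Cn1c(COc2cccc(C(=O)O)c2)nc2ccc(Oc3ccc(F)cn3)cc21` differs from compound 3 by 5-fluoropyridin-2-yl in place of 3-methylpyridin-2-yl on an oxygen on an aromatic ring. Among the measured compounds shown here, the methyl leaves, which alone would be expected to undo part of the rise seen because a number 0.50 log units higher from compound 1 to compound 3 (beyond the scatter); a fluorine enters in its place, and no measured step here covers that. The step from compound 3 is therefore expected to be modest and downward, a number 0.30 log units lower from compound 3 to compound 4 (within the scatter). Compound 4 is estimated at 0.6, between 0.2 and 1.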

Compound 4, distribution coefficient: 0.6
For compound 4 middle estimate and measured number coincide at the digits printed; measured number inside the range.
By their numbers in this assay, from the lowest: compounds 1, 4, 2 and 3 (each within the scatter of the next, the first and the last beyond it).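

In this assay, 5-fluoropyridin-2-yl on this oxygen stays within the scatter of all three earlier groups, with a number 0.30 log units lower from compound 3 to compound 4 (within the scatter), a number 0.20 log units lower from compound 2 to compound 4 (within the scatter) and a number 0.20 log units higher from compound 1 to compound 4 (within the scatter). Unlike either methyl, then, the fluorine gives no step beyond the scatter from compound 1, and compound 4 cannot be told apart from any of the other three compounds. Nothing available explains these numbers. On these data alone, what a nitrile, an amine or a methoxy group on this pyridine ring would do to the number remains open.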